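A few compounds are considered here, and "the series" means these few. Any claim that something is new, unique, unknown or untested is made for them only; others in the source may bear on it.

Compound 3 `Cc1cccc(NC(=O)Nc2ccc(Sc3nc(C)cc(C)n3)cc2)c1` carries a urea that joins a 3-methylphenyl group to a second ring bearing a sulfur-linked pyrimidine. In a functional assay on MCF7 cells (Homo sapiens) for cytotoxicity, read by MTT assay, with a stated time of 3 days (a higher number here means a weaker inhibitor, a lower number a stronger inhibitor), compound 3 gives 37000 nM. Compound 2 `Cc1cc(C)nc(Oc2ccc(NC(=O)Nc3ccc(Cl)cc3Cl)cc2)n1`, with an oxygen link and a dichlorophenyl group instead, gives 47800 nM in this assay; the two numbers sit within the usual scatter of each other, so neither can be called stronger. For compound 1 `Cc1cccc(NC(=O)Nc2ccc(Oc3nc(C)cc(C)n3)cc2)c1` the entry in this assay reads "not determined" (no result reported), so no number exists for compound 1. Compound 4 `Cc1cc(C)nc(Sc2ccc(NC(=O)Nc3ccc(F)cc3)cc2)n1` differs from compound 3 by 4-fluorophenyl in place of 3-methylphenyl on an amide-type nitrogen. Among the compounds with values here, no measured pair shows this change, so only a small shift, if any, beyond the scatter is expected in this assay. Compound 4 is therefore estimated at 40000 nM, between 12000 nM and 130000 nM, a step of a 1.1-fold higher number from compound 3 to compound 4 (0.03 log units; within the scatter).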

Compound 4, half-maximal inhibitory concentration: > 50000 nM
Compound 4: only a limit was reported; the forecaster's own chance of this, stated with the estimate: 25%; middle value at least 1.2-fold (0.09 log units) from the limit.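

Within the data shown here, this is the first readable single change on the amide-type nitrogen, with 4-fluorophenyl in place of 3-methylphenyl and the sulfur link kept. In this assay, from the compounds shown here alone, the change gives an at least 1.3-fold higher number from compound 3 to compound 4 (0.13 log units; that floor lies within the scatter), so the true size of the step stays unknown. The result for compound 4 is a limit, not a number: the limit of > 50000 nM in this assay, at which 1 of the 4 values shown sits.

Going by these compounds, whether a phenyl group carrying an amine or a carboxylic acid on this nitrogen would give a lower number stays open. So does the effect of 4-fluorophenyl with an oxygen link.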